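Swapping the quinoline ring in a Vero cell toxicity series

A few compounds are considered here, and "the series" means these few. Any claim that something is new, unique, unknown or untested is made for them only; others in the source may bear on it.

Measured compounds:
compound 1 `C=C1CC[C@@H]2[C@](C)(CO)[C@H](O)CC[C@@]2(C)[C@@H]1C/C=C1/C(=O)OC[C@H]1Oc1c(Cl)cc(Cl)c2cccnc12`, in an ADME assay on Vero cells (Chlorocebus sabaeus) for cytotoxicity, read by MTT assay, with a stated time of 48 h (on this read-out higher numbers stand for lower toxicity in this test and lower numbers for higher toxicity in this test), compound 1 gives 82500 nM
compound 2 `C=C1CC[C@@H]2[C@](C)(COC(C)=O)[C@H](O)CC[C@@]2(C)[C@@H]1C/C=C1/C(=O)OC[C@H]1Oc1cccc2ccc(C)nc12`, in this assay compound 2 gives 50600 nM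
compound 3 `C=C1CC[C@@H]2[C@](C)(CO)[C@H](O)CC[C@@]2(C)[C@@H]1C/C=C1/C(=O)OC[C@H]1Oc1cccc2ccc(C)nc12`, in this assay compound 3 gives 61400 nM

Compound 4 `C=C1CC[C@@H]2[C@](C)(COC(C)=O)[C@H](O)CC[C@@]2(C)[C@@H]1C/C=C1/C(=O)OC[C@H]1Oc1c(Cl)cc(Cl)c2cccnc12` has not yet been measured in this assay. It differs from compound 2 in one place: 5,7-dichloroquinolin-8-yl in place of 2-methylquinolin-8-yl on an oxygen on a saturated carbon. Exactly the same change turns compound 3 into compound 1: 5,7-dichloroquinolin-8-yl in place of 2-methylquinolin-8-yl on an oxygen on a saturated carbon. That earlier step gave a 1.3-fold higher number from compound 3 to compound 1 (0.13 log units; within the scatter). The two starting cores, compound 3 and compound 2, differ in another place: acetyl in place of hydrogen on an oxygen on a saturated carbon; this step gave a 1.2-fold higher number from compound 2 to compound 3 (0.08 log units; within the scatter). All three measured numbers lie within the scatter of one another, so none of the compounds can be called more or less toxic than another. Because a 1.3-fold higher number from compound 3 to compound 1 (0.13 log units; within the scatter) barely moved the number, a step of similar size is expected here: a 1.3-fold higher number from compound 2 to compound 4 (0.12 log units; within the scatter). Compound 4 is therefore estimated at 66000 nM, most likely falling between 33000 nM and 130000 nM.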

Compound 4, half-maximal cytotoxic concentration: 85000 nM
Estimate against measurement, compound 4: 1.3-fold (0.11 log units) below, and the stated range covers the measured number.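

In this assay, putting 5,7-dichloroquinolin-8-yl in place of 2-methylquinolin-8-yl gives a 1.7-fold higher number from compound 2 to compound 4 (0.23 log units; within the scatter), and this step agrees with the one seen on the other core: the same change on two cores in this assay, a 1.3-fold higher number (0.13 log units; within the scatter) from compound 3 to compound 1 and a 1.7-fold higher number (0.23 log units; within the scatter) from compound 2 to compound 4, 1.3-fold (0.10 log units) apart, within the scatter of two such steps. Putting acetyl in place of hydrogen gives a 1.0-fold higher number from compound 1 to compound 4 (0.01 log units; within the scatter), which also agrees with its earlier counterpart: the same change on two cores in this assay, a 1.2-fold higher number (0.08 log units; within the scatter) from compound 2 to compound 3 and a 1.0-fold lower number (0.01 log units; within the scatter) from compound 4 to compound 1, 1.3-fold (0.10 log units) apart, within the scatter of two such steps. Each change therefore behaves alike on the two cores shown, but every step lies within the scatter, so this shows only that neither change measurably moved the number here, not that either would do the same on another core.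

The compounds shown leave open whether a quinoline ring carrying an amine or a carboxylic acid would move the number beyond the scatter. The same question stands for a longer chain in place of the acetyl.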